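Swapping a dimethylamino tail for a hydroxy group

The source may hold more compounds than are shown below. What is called first, only, known or untested is meant among the compounds shown, and "the series" means these compounds.

In an assay on NK92 cells for inhibition of interleukin-15 (Homo sapiens), read by AlphaScreen, with stated times of 30 min and 1 h (on this read-out lower numbers stand for stronger inhibition and higher numbers for weaker inhibition), compound 1 `CCOC(CCn1c(Cc2nn(C)c(=O)c3ccccc23)nnc1SCCCCCCCC(=O)Nc1ccc(Cl)cc1Cl)OCC` gives 30000 nM. Compound 2 `CN(C)CCCn1c(Cc2nn(C)c(=O)c3ccccc23)nnc1SCCCCCCCC(=O)Nc1ccc(Cl)cc1Cl` carries a (dimethylamino)methyl group where compound 1 carries a diethoxymethyl group. In this assay compound 2 reaches the limit of > 30000 nM, which is a limit and not a measured number. The step of a number no lower from compound 1 to compound 2 (the limit leaves the size open) therefore cannot be sized; what the data show is that compound 2 sits at the limit of > 30000 nM in this assay, at which 1 of the 2 values shown sits. Compound 3 `Cn1nc(Cc2nnc(SCCCCCCCC(=O)Nc3ccc(Cl)cc3Cl)n2CCCO)c2ccccc2c1=O` differs from compound 2 by hydroxy in place of dimethylamino on a saturated chain carbon, three bonds along the chain from an aromatic nitrogen. Among the measured compounds shown here, only one measured step touches the same part of the molecule, and its size is not readable, so it gives little guidance beyond showing that both measured compounds inhibit weakly. Compound 3 is expected to remain weak as well, with the step of a number no higher from compound 2 to compound 3 (the limit leaves the size open) expected to stay within the scatter or to leave the result at a limit once more. Compound 3 is therefore estimated at 30000 nM, within a range from 10000 nM to 100000 nM, with a real chance that this assay again reports only a limit.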

Compound 3, half-maximal inhibitory concentration: > 30000 nM
Compound 3 gave a limit, no number; the forecaster's own chance of this, stated with the estimate: 60%; the middle value sits exactly at the limit.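

In this assay compound 3 gives > 30000 nM, which is a limit of the assay and not a number. Hydroxymethyl in place of diethoxymethyl on a saturated chain carbon, two bonds along the chain from an aromatic nitrogen, gives a number no lower from compound 1 to compound 3 (the limit leaves the size open). The steps to compound 3 from compound 2 and from compound 1 cannot be read, so neither change can be given a size. What is new is that the end of the 3-carbon chain on the aromatic nitrogen now carries a hydroxy group, with a hydrogen-bond donor that dimethylamino lacks, and this change still yields no measured number, leaving the series here: the limit of > 30000 nM in this assay, at which 2 of the 3 values shown sit.

From the compounds shown here alone, whether a carboxylic acid or a primary amine at the end of this chain, or a longer chain, would bring a value under the limit stays open. The compounds shown also leave open whether any group at this position can do so while the rest of the molecule stays the same.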